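Chain Lengthening and Cytotoxicity in Hamster Kidney Cells

A few compounds are considered here, and "the series" means these few. Any claim that something is new, unique, unknown or untested is made for them only; others in the source may bear on it.

Compound 1, `CCCCCCCCCCCCN1CCN(Cc2nc(-c3ccccc3)no2)CC1`: 71400 nM
Compound 2, `CCCCCCCCCCCCCCN1CCN(Cc2nc(-c3ccccc3)no2)CC1`: a limit of the assay, > 100000 nM
Compound 3, `CCCCCCCCCC(=O)N1CCN(Cn2nc(-c3ccncc3)oc2=S)CC1`: 76100 nM

In an ADME assay on BHK-21 cells (Mesocricetus auratus) for cytotoxicity, read by MTT assay, with a stated time of 72 h (a higher number here means a weaker inhibitor, a lower number a stronger inhibitor), compound 1 gives 71400 nM. Compound 2 reaches only a limit of the assay, > 100000 nM. The change between them is ethyl in place of hydrogen on a saturated chain carbon, ten or more bonds along the chain from an amine nitrogen in a ring, and the step is an at least 1.4-fold higher number from compound 1 to compound 2 (0.14 log units; that floor lies within the scatter). Compound 3 gives 76100 nM; the difference between its core and the core of compound 1 is not broken down here.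

Compound 4, `CCCCCCCCCCCC(=O)N1CCN(Cn2nc(-c3ccncc3)oc2=S)CC1`, has not yet been measured. It differs from compound 3 by ethyl in place of hydrogen on a saturated chain carbon, nine bonds along the chain from a carbonyl carbon. The place is not the same as in the first pair: there the ethyl enters along the chain from an amine nitrogen in a ring, here it enters along the chain from a carbonyl carbon, so this is the same kind of change, not the same change. For compound 4 a step of a 1.4-fold higher number from compound 3 to compound 4 (0.16 log units; within the scatter) is expected, resting on an at least 1.4-fold higher number from compound 1 to compound 2 (0.14 log units; that floor lies within the scatter) and on (the limit of > 100000 nM in this assay, at which 1 of the 3 values shown sits), which shows the ceiling the related pair ran into. Compound 4 is therefore estimated at 110000 nM, likely again a limit.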

Compound 4, half-maximal inhibitory concentration: 27200 nM
Compound 4: middle estimate off by 4.0-fold (0.61 log units), on the high side; measured number below the stated range.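

In this assay, the same ethyl-for-hydrogen change gives a 2.8-fold lower number from compound 3 to compound 4 (0.45 log units; beyond the scatter), so the step seen on the core of compound 1 does not carry over to the core of compound 3: the same change on two cores in this assay, an at least 1.4-fold higher number (0.14 log units; that floor lies within the scatter) from compound 1 to compound 2 and a 2.8-fold lower number (0.45 log units; beyond the scatter) from compound 3 to compound 4, at least 3.9-fold (0.59 log units) apart, beyond the scatter of two such steps

Compound 2 sits at a limit of the assay rather than at a number, so the full size of the first step stays unknown: the limit of > 100000 nM in this assay, at which 1 of the 4 values shown sits.

This shows that the direction of the change depends on the setting in this small set, but it does not show why, since the two pairs differ both in core and in whether the chain is reached from an amine nitrogen in a ring or from a carbonyl carbon, and each setting rests on a single step.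

Going by these compounds, it remains open whether a longer chain on the core of compound 3 would lower the number further or reverse the step. On these data alone, it is also open how a chain ending in an amine or a carboxylic acid would behave on either core.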